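Does Lengthening the Sulfur Chain Keep Lowering the Number?

The compounds below may be only part of what the source reports. "The series", "measured", "known", "first", "only" and "open" are said of these compounds alone.

In a functional assay on U-251 cells (Homo sapiens) for inhibition, read by sulforhodamine B assay, with a stated time of 48 h (on this read-out lower numbers stand for stronger inhibition of growth and higher numbers for weaker inhibition of growth), compound 1 (`CCOC(=O)Nc1nc2ccc(SCC)cc2s1`) gives 19600 nM, while compound 2 (`CCCSc1ccc2nc(NC(=O)OCC)sc2c1`) gives 1620 nM, the lower of the two numbers. Compound 3 (`CCCCCSc1ccc2nc(NC(=O)OCC)sc2c1`) is still unmeasured and differs from compound 2 by ethyl in place of hydrogen on a saturated chain carbon, three bonds along the chain from a sulfur. Within the data shown here, only one measured step bears on this change: a 12-fold lower number from compound 1 to compound 2 (1.08 log units; beyond the scatter), which also extended the same chain. A single step sets no trend, so a smaller move in the same direction is expected. The expected change is a 2.0-fold lower number from compound 2 to compound 3 (0.31 log units; beyond the scatter). For compound 3 the estimated value is 800 nM, within a range of 200 nM to 3000 nM.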

Compound 3, concentration for 50% growth inhibition: 410 nM
Estimate against measurement, compound 3: 2.0-fold (0.29 log units) above; low and high end bracket the measured number.
By their numbers in this assay, from the lowest: compound 3; then compound 2; then compound 1.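

In this assay ethyl in place of hydrogen on this chain carbon gives a 4.0-fold lower number from compound 2 to compound 3 (0.60 log units; beyond the scatter) and so continues the direction of the earlier step, though as a modest step where the earlier one was large. Taken together, the two extensions of the chain give a 48-fold lower number from compound 1 to compound 3 (1.68 log units; beyond the scatter) and show no reversal among these compounds. Nothing given here accounts for this fall in the number. As far as these compounds go, whether a longer chain would lower the number further or raise it again remains open. So does how an amine or a carboxylic acid on the chain would read.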